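Silicon in place of butyl on the five-membered ring

A few compounds are considered here, and "the series" means these few. Any claim that something is new, unique, unknown or untested is made for them only; others in the source may bear on it.

Measured so far:
Compound 1, `CCCCCc1ccc(-c2cn(C/C=C3\OC(=O)C(OCc4ccccc4)=C3OCc3ccccc3)nn2)cc1`: in a functional assay on HCT-116 cells (Homo sapiens) for antiproliferative activity, read by MTT assay, with a stated time of 72 h (a lower number here means a stronger inhibitor, a higher number a weaker inhibitor), compound 1 gives > 100000 nM, a limit of the assay.
Compound 3, `COc1ccc(-c2cn(C/C=C3\OC(=O)C(OCc4ccccc4)=C3OCc3ccccc3)nn2)cc1`: in this assay compound 3 gives > 100000 nM, likewise a limit.
Compound 2, `CCCCc1cn(C[C@H](O)[C@H]2OC(=O)C(OCc3ccccc3)=C2OCc2ccccc2)nn1`: in this assay compound 2 gives 10400 nM.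

For the measured compounds named here, compound 2 therefore stands as the only number in the set; the other two values sit at the limit of > 100000 nM in this assay, at which 2 of the 3 values shown sit. Going by the values given here, the single measured step, a step that the two limits leave unreadable from compound 1 to compound 3, runs between two limits and its size cannot be read, and it concerns a different pair of groups on a different carbon. Compound 4, `C[Si](C)(C)c1cn(C[C@H](O)[C@H]2OC(=O)C(OCc3ccccc3)=C2OCc2ccccc2)nn1`, differs from compound 2 by a group of 4 heavy atoms (3 carbon, 1 silicon; no ring) in place of a group of 4 heavy atoms (4 carbon; no ring), on an aromatic carbon. Among the compounds with values here, no measured step touches a group on the five-membered aromatic ring with 3 nitrogen, so there is nothing from which to expect a step in this assay beyond the usual scatter in either direction. The expectation is that compound 4 sits close to compound 2, with an estimated step of no change at the digits printed from compound 2 to compound 4 (within the scatter). Compound 4 is thus estimated at 10400 nM, ranging from 3500 nM to 35000 nM.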

Compound 4, half-maximal inhibitory concentration: 31800 nM
Compound 4: the middle estimate sits 3.1-fold (0.49 log units) below what was measured; low and high end bracket the measured number.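

In this assay the exchange of butyl for the silicon-bearing group gives a 3.1-fold higher number from compound 2 to compound 4 (0.49 log units; beyond the scatter), so the group on this aromatic carbon of the five-membered aromatic ring does affect the read-out. For the compounds shown here, this is the only readable step and the only one at this position, and it arises although both groups have 4 heavy atoms, no ring, and no hydrogen-bond donors or acceptors. No measured property in hand accounts for the step.

As far as these compounds go, a single step gives no trend, so whether a longer chain, an amine or a carboxylic acid at this position would move the value further remains open. The step between compound 1 and compound 3 cannot be read, which leaves the effect of the group on their aromatic carbon open as well: the limit of > 100000 nM in this assay, at which 2 of the 4 values shown sit.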